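Z to E double-bond switch on the methyl analogue

The compounds below may be only part of what the source reports. "The series", "measured", "known", "first", "only" and "open" are said of these compounds alone.

Compound 2 `C/C(C(=O)NC1CC1)=C(\C)c1ccc(C)cc1` gives 500 mg/kg in a toxicity assay on the whole organism (strain Icem-CET (SPF Caw)) for cytotoxicity, with Mus musculus as the target (on this read-out higher numbers stand for an effect only at larger amounts of compound and lower numbers for an effect already at smaller amounts), the top of the two numbers shown, though only by a margin within the scatter; its nearest neighbour is compound 1 `C/C(C(=O)NC1CC1)=C(\C)c1ccc(Br)cc1` with 450 mg/kg, and a 1.1-fold higher number from compound 1 to compound 2 (0.05 log units; within the scatter) stays within the scatter. Compound 3 `C/C(C(=O)NC1CC1)=C(/C)c1ccc(C)cc1` is the next candidate: the two compounds have the same atoms and bonds and differ only in configuration as drawn: 1 of 1 stereo elements differ; a double bond is drawn Z in compound 2 and E in compound 3. Going by the values given here, no measured step touches this element, the single known step swaps a ring substituent, so no change beyond the scatter is expected; the estimated step is no change at the digits printed from compound 2 to compound 3 (within the scatter). Compound 3 is therefore estimated at 500 mg/kg, with a range of 250 mg/kg to 1000 mg/kg.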

Compound 3, dose for half-maximal effect: 300 mg/kg
For compound 3 the middle estimate is 1.7-fold (0.22 log units) above the measured one; measured number inside the range.
By their numbers in this assay, from the lowest: compounds 3, 1 and 2 (each within the scatter of the next).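

The double-bond switch on the methyl analogue gives a 1.7-fold lower number from compound 2 to compound 3 (0.22 log units; within the scatter) in this assay, so drawing this bond Z or E has no effect here that can be told from the scatter. Going by these compounds alone, this is the first read on configuration, as the earlier step, a 1.1-fold higher number from compound 1 to compound 2 (0.05 log units; within the scatter), concerned only the aromatic substituent. The comparison is clean in structure: the fact that compounds 2 and 3 differ only in the configuration as drawn.

The switch is shown only with methyl on the aromatic carbon, so its outcome with bromo remains open. Also open, from the compounds shown here alone, is whether an amine or a carboxylic acid at that carbon would move the number beyond the scatter.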